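The source may report more compounds than this note shows. Statements on the series, on what has been measured and on what is new or still open speak of the compounds shown alone.

Compound 1 (`Cc1cc(=O)c2c(O)cc(OCc3ccco3)c([C@H]3CCN(C)C[C@H]3O)c2o1`) gives 17%
Compound 2 (`CCN(CC)Cc1c(O)c([C@H]2CCN(C)C[C@H]2O)c2oc(C)cc(=O)c2c1O`) gives 17%

In a functional assay on Caco-2 cells (Homo sapiens) for inhibition, read by MTT assay, with a stated time of 48 h, tested at 10 uM (a higher number here means more inhibition of growth at the concentration tested, a lower number less inhibition of growth), compound 2 gives 17% and so stands level with compound 1 at 17%, within the scatter of repeated measurements. Compound 3 (`Cc1cc(=O)c2c(O)c(CN3CCCC3)c(O)c([C@H]3CCN(C)C[C@H]3O)c2o1`) has not yet been measured. It departs from compound 2 in one place (pyrrolidin-1-yl in place of diethylamino on a saturated chain carbon bound to an aromatic carbon), with pyrrolidin-1-yl in place of diethylamino on a saturated chain carbon bound to an aromatic carbon. Among the compounds with values here, no step between measured compounds shows what such a change does, so the expectation rests on compound 2 at 17% and on the structural change alone. The expected step of a number 3 percentage points higher from compound 2 to compound 3 (within the scatter) is estimated to lie within the scatter, with no firm direction. The estimate for compound 3 is 20%, with an expected range from 8% to 35%.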

Compound 3, percent growth inhibition at one concentration: 22%
For compound 3 the middle estimate is 2 percentage points below the measured one, and the stated range covers the measured number.
By their numbers in this assay, from the lowest: compounds 1, 2 and 3 (each within the scatter of the next).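

In this assay, within the data shown here, pyrrolidin-1-yl in place of diethylamino on a saturated chain carbon bound to an aromatic carbon gives a number 5 percentage points higher from compound 2 to compound 3 (within the scatter) and so provides the first reading of this change. At this place, therefore, the open diethylamino group and the five-membered ring of the same heavy-atom count are not told apart by this measurement, and compound 3 stands at 22%. No measured information bears on what lies behind this result.

The compounds shown leave open whether a morpholin-4-yl or piperidin-1-yl group at this place, or a longer chain leading to the amine, would carry the number beyond the scatter. They also leave open whether the same exchange would read alike on a different core or at another concentration.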